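A Carboxyphenyl Swap Tested on Compound 3

The compounds below may be only part of what the source reports. "The series", "measured", "known", "first", "only" and "open" are said of these compounds alone.

Three compounds have been measured in an assay on HEK293 cells for antagonist activity at transient receptor potential M8 protein (Canis lupus familiaris), read by fluorescence and calcium flux, with a stated time of 5 min; a lower number here means a stronger inhibitor, a higher number a weaker inhibitor:

Compound 1 `O=C(C(Nc1ccccc1F)c1ccc(C(F)(F)F)cc1)N1CCCC1c1ccccn1` gives 25 nM.
Compound 2 `O=C(O)c1cccc(C2CCCN2C(=O)C(Nc2ccccc2F)c2ccc(C(F)(F)F)cc2)c1` gives 40 nM.
Compound 3 `O=C(C(Nc1ccccc1F)c1cc2ccccc2s1)N1CCCC1c1ccccn1` gives 8 nM.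

Compound 3 stands lowest of the three, and its steps to compound 1 and to compound 2 both lie beyond the scatter, so it is the strongest inhibitor measured so far. Compound 4 `O=C(O)c1cccc(C2CCCN2C(=O)C(Nc2ccccc2F)c2cc3ccccc3s2)c1` differs from compound 3 in one place: 3-carboxyphenyl in place of pyridin-2-yl on a saturated ring carbon. The same exchange has already been made once, between compound 1 and compound 2, where it gave a 1.6-fold higher number from compound 1 to compound 2 (0.20 log units; within the scatter). For the measured compounds named here, that single step is the only evidence bearing on this change, and it suggests no shift beyond the scatter in this assay, with a slight lean toward a higher number. Compound 4 is therefore estimated at 13 nM, within a range of 5 nM to 35 nM. The estimated step is a 1.6-fold higher number from compound 3 to compound 4 (0.21 log units; within the scatter).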

Compound 4, half-maximal inhibitory concentration: 78 nM
Compound 4: the middle estimate sits 6.0-fold (0.78 log units) below what was measured, outside the stated range (above it).
By their numbers in this assay, from the lowest: compound 3; then compounds 1, 2 and 4 (each within the scatter of the next, the first and the last beyond it).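

With 1-benzothiophen-2-yl on the chain carbon, the exchange at this ring carbon gives a 9.8-fold higher number from compound 3 to compound 4 (0.99 log units; beyond the scatter), so the size of this change depends on the group elsewhere in the molecule: the same change on two cores in this assay, a 1.6-fold higher number (0.20 log units; within the scatter) from compound 1 to compound 2 and a 9.8-fold higher number (0.99 log units; beyond the scatter) from compound 3 to compound 4, 6.1-fold (0.78 log units) apart, beyond the scatter of two such steps. With 3-carboxyphenyl on the ring carbon, 1-benzothiophen-2-yl brings a 2.0-fold higher number from compound 2 to compound 4 (0.29 log units; within the scatter), so the lower number seen with pyridin-2-yl does not carry over: the same change on two cores in this assay, a 3.1-fold lower number (0.49 log units; beyond the scatter) from compound 1 to compound 3 and a 2.0-fold higher number (0.29 log units; within the scatter) from compound 2 to compound 4, 6.1-fold (0.78 log units) apart, beyond the scatter of two such steps.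

Whether the carboxylic acid itself accounts for the larger step on compound 4 remains open. So does how a methyl ester, a primary amide or an unsubstituted phenyl at this ring carbon would read alongside 1-benzothiophen-2-yl.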